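Bromo to hydroxy: working notes on the series

The source may report more compounds than this note shows. Statements on the series, on what has been measured and on what is new or still open speak of the compounds shown alone.

Measured in a functional assay on A-431 cells (Homo sapiens) for inhibition, read by MTT assay, with a stated time of 72 h; on this read-out lower numbers stand for stronger inhibition and higher numbers for weaker inhibition:
- compound 1 `COc1ccc(-c2nnc(SCCCN3CCN(c4nc5ccccc5s4)CC3)o2)cc1`: 56200 nM
- compound 2 `Cc1ccc(-c2nnc(SCCCN3CCN(c4nc5ccccc5s4)CC3)o2)cc1`: 61600 nM
- compound 3 `Brc1ccc(-c2nnc(SCCCN3CCN(c4nc5ccccc5s4)CC3)o2)cc1`: 51600 nM

In this assay compound 3, at 51600 nM, stands level with the other two measured compounds. The steps that reach it are a 1.1-fold lower number from compound 1 to compound 3 (0.04 log units; within the scatter) and a 1.2-fold lower number from compound 2 to compound 3 (0.08 log units; within the scatter). The remaining step at the same place, a 1.1-fold higher number from compound 1 to compound 2 (0.04 log units; within the scatter), is equally small.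

Compound 4 `Oc1ccc(-c2nnc(SCCCN3CCN(c4nc5ccccc5s4)CC3)o2)cc1` carries hydroxy in place of bromo on an aromatic carbon, the change from 4-bromophenyl to 4-hydroxyphenyl: hydroxy in place of bromo on an aromatic carbon. All three measured steps bear on this change, since each swaps the group at this same place. Methoxy, methyl and bromo have so far given values within the scatter of one another, and no measured compound goes against this. Among the measured compounds shown here, no measured compound carries hydroxy, however, so the new group is untested and the range is kept wide. No step beyond the scatter is expected in this assay. The expected step is a 1.1-fold higher number from compound 3 to compound 4 (0.03 log units; within the scatter). For compound 4 the estimated value is 55000 nM, with an expected range of 25000 nM to 100000 nM.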

Compound 4, half-maximal inhibitory concentration: 54700 nM
Compound 4: middle estimate off by 1.0-fold (0.00 log units), on the high side, and the stated range covers the measured number.
By their numbers in this assay, from the lowest: compounds 3, 4, 1 and 2 (each within the scatter of the next).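

Hydroxy in place of bromo on an aromatic carbon, para to a large group, swaps a group with no hydrogen-bond donor or acceptor for one with one of each, yet in this assay the result is a 1.1-fold higher number from compound 3 to compound 4 (0.03 log units; within the scatter). The comparisons with the other two groups agree: hydroxy in place of methyl gives a 1.1-fold lower number from compound 2 to compound 4 (0.05 log units; within the scatter), and hydrogen in place of methyl on the oxygen gives a 1.0-fold lower number from compound 1 to compound 4 (0.01 log units; within the scatter). Across the four compounds shown, this position therefore tolerates a hydrogen-bond donor without a step beyond the scatter, no compound goes against this, and nothing available indicates why the number stays flat.

On these data alone, it remains open whether this flatness extends to groups of another kind at the same place, such as an amine, a carboxylic acid or a longer chain, any of which would test the position more severely than these four single-atom or small groups. As far as these compounds go, it is also open whether a change elsewhere on the shared core, rather than at this position, can move the number beyond the scatter.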